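The source may report more compounds than this note shows. Statements on the series, on what has been measured and on what is new or still open speak of the compounds shown alone.

Measured so far in an ADME assay on HEp-2 cells (Homo sapiens) for cytotoxicity; a higher number here means that more compound is tolerated, a lower number that less compound is tolerated:
- compound 1 `O=C1CS(=O)(=O)c2ccccc2N1Cc1nc2ccccc2n1CCCCF`: 211000 nM
- compound 2 `CC(C)CCn1c(CN2C(=O)C(Cc3ccccc3)C(=O)c3ccccc32)nc2ccccc21`: 20100 nM
- compound 3 `CN1C(=O)N(Cc2nc3ccccc3n2CCCS(C)(=O)=O)c2ccccc2S1(=O)=O`: 34500 nM

Compound 1 has the highest number of the three, and compound 3 and compound 2 both lie below it, beyond the scatter. Compound 4 `CC(C)CCn1c(CN2C(=O)CS(=O)(=O)c3ccccc32)nc2ccccc21` keeps the core of compound 1 and differs from it by one change: isopropyl in place of 2-fluoroethyl on a saturated chain carbon, two bonds along the chain from an aromatic nitrogen. This places isopropyl in place of 2-fluoroethyl on a saturated chain carbon, two bonds along the chain from an aromatic nitrogen; cut one bond further out, it reads 4-fluorobutyl to isopentyl.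

For the measured compounds named here, no measured pair isolates this change, so the expectation rests on little. Going by the values given here, compound 2 is the only measured compound with the isopentyl chain, on a different core, and it gives 20100 nM. A fall in this assay beyond the scatter is therefore expected, though a smaller one than the gap between the values of compound 1 and compound 2. The expected change is a 3.8-fold lower number from compound 1 to compound 4 (0.58 log units; beyond the scatter). For compound 4 the estimated value is 55000 nM, with an expected range of 18000 nM to 170000 nM.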

Compound 4, half-maximal cytotoxic concentration: 63000 nM
Estimate against measurement, compound 4: 1.1-fold (0.06 log units) below, and the stated range covers the measured number.
By their numbers in this assay, from the lowest: compounds 2, 3 and 4 (each within the scatter of the next, the first and the last beyond it); then compound 1.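

For the compounds shown here, on the core of compound 1, the first matched step in this assay is a 3.3-fold lower number from compound 1 to compound 4 (0.52 log units; beyond the scatter) and it comes from isopropyl in place of 2-fluoroethyl on a saturated chain carbon, two bonds along the chain from an aromatic nitrogen. The number at this position therefore responds to the end of the chain, even with the heavy-atom count of the swapped group unchanged, although the step is only modest. Nothing measured here accounts for the step.

Going by these compounds alone, the single step combines loss of the fluorine with gain of the branch, so an unbranched pentyl chain or a 4-hydroxybutyl chain would be needed to separate the two. From the compounds shown here alone, whether the same step holds on the cores of compound 2 and compound 3 remains open.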